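A few compounds are considered here, and "the series" means these few. Any claim that something is new, unique, unknown or untested is made for them only; others in the source may bear on it.

Compound 1 `COc1cc2c(Oc3ccc(NC(=O)c4cc(-c5ccc(C)cc5)ccn4)cc3F)ccnc2cc1OCCCN1CCCC1` gives 160 nM in a functional assay on NCI-H460 cells (Homo sapiens) for cytotoxicity, read by MTT assay, with a stated time of 72 h; a lower number here means a stronger inhibitor, a higher number a weaker inhibitor. Compound 2 `COc1cc2c(Oc3ccc(NC(=O)c4cc(-c5ccc(C(F)(F)F)cc5)ccn4)cc3F)ccnc2cc1OCCCN1CCCC1` gives 250 nM in this assay; the step of a 1.6-fold higher number from compound 1 to compound 2 (0.19 log units; within the scatter) leaves compound 2 at the top of the two numbers shown, with compound 1 its nearest neighbour and within the scatter. Compound 3 `COc1ccc(-c2ccnc(C(=O)Nc3ccc(Oc4ccnc5cc(OCCCN6CCCC6)c(OC)cc45)c(F)c3)c2)c(OC)c1` differs from compound 2 by 2,4-dimethoxyphenyl in place of 4-(trifluoromethyl)phenyl on an aromatic carbon. Within the data shown here, the only step bearing on this exchange of the pendant aryl ring is a 1.6-fold higher number from compound 1 to compound 2 (0.19 log units; within the scatter), which stayed within the scatter, so no step beyond the scatter is expected in this assay for compound 3. The expected step is a 1.1-fold lower number from compound 2 to compound 3 (0.06 log units; within the scatter). Compound 3 is estimated at 220 nM, with a range from 80 nM to 600 nM.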

Compound 3, half-maximal inhibitory concentration: 520 nM
Compound 3: the middle estimate sits 2.4-fold (0.37 log units) below what was measured; the measured number falls inside the stated range.
By their numbers in this assay, from the lowest: compounds 1 and 2 (each within the scatter of the next); then compound 3.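

In this assay, among these compounds, the entering 2,4-dimethoxyphenyl gives a 2.1-fold higher number from compound 2 to compound 3 (0.32 log units; beyond the scatter) and a 3.3-fold higher number from compound 1 to compound 3 (0.51 log units; beyond the scatter) as the first steps beyond the scatter at this aromatic carbon opposite the ring nitrogen. The pendant aryl ring here is therefore not freely exchangeable, although both steps are modest and rest on this one replacement. Nothing available accounts for these steps. On these data alone, whether both methoxy groups are needed for the rise stays open, since a single methoxy group on this ring would be required to separate them. As far as these compounds go, how an amine or a carboxylic acid on the ring would read in this assay also stays open.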